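The source may report more compounds than this note shows. Statements on the series, on what has been measured and on what is new or still open speak of the compounds shown alone.

Compound 1 `O=S(=O)(Nc1ccc2oc(-c3ccccc3)nc2c1)c1cccc(O)c1` and compound 2 `COc1ccc(Cl)cc1S(=O)(=O)Nc1ccc2oc(-c3ccccc3)nc2c1` share one core and differ only in the group on the sulfonyl sulfur. In an assay on isolated protein for inhibition of malate dehydrogenase, mitochondrial (Sus scrofa), with stated times of 45 min and 30 min (on this read-out lower numbers stand for stronger inhibition and higher numbers for weaker inhibition), compound 1 gives no number but a limit of the assay, > 63000 nM. Compound 2 likewise gives only a limit of the assay, > 63000 nM. For the measured compounds named here, the step that the two limits leave unreadable from compound 1 to compound 2 therefore cannot be sized, and compound 2 stands at the same limit as the one other measured compound, so that the whole evidence is the limit of > 63000 nM in this assay, at which 2 of the 2 values shown sit. Compound 3 `O=S(=O)(Nc1ccc2oc(-c3ccccc3)nc2c1)c1ccccc1O` is not yet measured; it differs from compound 2 by 2-hydroxyphenyl in place of 5-chloro-2-methoxyphenyl on a sulfonyl sulfur. Going by the values given here, the single measured step at the sulfonyl sulfur bears on this change but its size is unreadable, so no step beyond the scatter can be expected in either direction in this assay. Compound 3 is therefore expected near 100000 nM, with a range from 30000 nM to 400000 nM, most likely again reported only as a limit. The expected step is a step that the limit leaves unreadable from compound 2 to compound 3.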

Compound 3, half-maximal inhibitory concentration: > 63000 nM
Compound 3: no number, only a limit; the forecaster's own chance of this, stated with the estimate: 85%; the middle value does not contradict the limit.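

In this assay, for the compounds shown here, compound 3 gives > 63000 nM which is only a limit of the assay, so no step among compound 1, compound 2 and compound 3 can be read. The compounds shown leave open whether any group on the sulfonyl sulfur of the shared core gives measurable inhibition.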